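The source may hold more compounds than are shown below. What is called first, only, known or untested is meant among the compounds shown, and "the series" means these compounds.

Measured so far:
- compound 1, `Cc1nc(-c2ccc(Cl)cc2)sc1C(=O)CSc1nc(-c2ccc(Cl)cc2)c(C#N)c(=O)[nH]1`: 53000 nM
- compound 2, `COc1ccc(-c2nc(C)c(C(=O)CSc3nc(-c4ccc(OC)c(OC)c4)c(C#N)c(=O)[nH]3)s2)cc1`: 12500 nM

Both numbers come from a functional assay on U-87MG ATCC cells for antiproliferative activity against U-87 MG (Homo sapiens), read by MTT assay, with a stated time of 48 h; on this read-out higher numbers stand for weaker inhibition and lower numbers for stronger inhibition. Compound 2 stands at the lowest of the two values; the only other, compound 1, sits higher by a gap that is beyond the usual scatter, so on these two compounds compound 2 is the stronger inhibitor. Compound 1 carries 4-chlorophenyl at both ends of the shared core; compound 2 carries methoxy-bearing aryl groups at both ends.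

Compound 3, `COc1ccc(-c2nc(C)c(C(=O)CSc3nc(-c4ccc(Cl)cc4)c(C#N)c(=O)[nH]3)s2)cc1`, has not yet been measured in this assay. It differs from compound 2 in one place: 4-chlorophenyl in place of 3,4-dimethoxyphenyl on an aromatic carbon. Compound 3 thereby pairs the 4-methoxyphenyl end of compound 2 with the 4-chlorophenyl end of compound 1. Within the data shown here, no step between measured compounds isolates this single change. Since compound 1, with 4-chlorophenyl at both ends, gives 53000 nM, the change is expected to move toward weaker inhibition by a modest step, near the edge of the scatter, with the estimated step being a 2.0-fold higher number from compound 2 to compound 3 (0.30 log units; within the scatter). Compound 3 is estimated at 25000 nM, with a range from 8000 nM to 80000 nM.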

Compound 3, half-maximal inhibitory concentration: 45900 nM
Compound 3: the middle estimate sits 1.8-fold (0.26 log units) below what was measured; measured number inside the range.
By their numbers in this assay, from the lowest: compound 2; then compounds 3 and 1 (each within the scatter of the next).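

In this assay, the position on the six-membered aromatic ring with 2 nitrogen, ortho to the cyano group, now has its first single-change reading: 4-chlorophenyl in place of 3,4-dimethoxyphenyl gives a 3.7-fold higher number from compound 2 to compound 3 (0.56 log units; beyond the scatter) and so costs inhibition by a margin beyond the scatter. The other end of the molecule, with 4-chlorophenyl held fixed at this position, gives no such separation: methoxy in place of chloro gives a 1.2-fold lower number from compound 1 to compound 3 (0.06 log units; within the scatter) and so leaves compound 1 and compound 3 within the scatter of each other. Among these three compounds, only the change at the first position gives a step beyond the scatter, and no accompanying measurement bears on the reason for this difference.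

Going by these compounds, the methoxy change at the other end has been read only with 4-chlorophenyl at the first position, so its size alongside 3,4-dimethoxyphenyl remains open. Also open, on these data alone, is whether both methoxy groups of 3,4-dimethoxyphenyl are needed, and how a single methoxy group, an amine or a carboxylic acid on that phenyl ring would compare.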